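The source may report more compounds than this note shows. Statements on the series, on what has been measured and on what is new or still open speak of the compounds shown alone.

Measured so far, in an assay on isolated protein for binding affinity to 5-hydroxytryptamine receptor 3A (Homo sapiens); on this read-out lower numbers stand for stronger inhibition and higher numbers for weaker inhibition:
compound 1 `COc1ccccc1-c1cc(C2CCN(C)C2)ccc1Cl`: 420 nM
compound 2 `CNCc1ccc(Cl)c(-c2ccccc2OC)c1`: > 10000 nM

Compound 2 sits at the assay limit of the limit of > 10000 nM in this assay, at which 1 of the 2 values shown sits, so only a bound is known for it. Compound 3 `CCCNCc1ccc(Cl)c(-c2ccccc2OC)c1` differs by ethyl in place of hydrogen on a saturated chain carbon bound to an amine nitrogen. Within the data shown here, the only measured step, an at least 23-fold higher number from compound 1 to compound 2 (1.37 log units; beyond the scatter), concerns a different change and gives no direct guide to an ethyl added at this position. Compound 3 is therefore expected to stay weak, with a step that the limit leaves unreadable from compound 2 to compound 3 as the expected step and, most probably, again a limit rather than a number. Estimate for compound 3: 15000 nM, range 4000 nM to 60000 nM.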

Compound 3, inhibition constant: > 10000 nM
Compound 3 ended at the assay's limit (the forecaster's own chance of this, stated with the estimate: 70%); the middle value does not contradict the limit.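

In this assay compound 3 gives > 10000 nM, which is a limit and not a number. With (propylamino)methyl in place of 1-methylpyrrolidin-3-yl there is an at least 23-fold higher number from compound 1 to compound 3 (1.37 log units; beyond the scatter), so ethyl on the saturated chain carbon bound to an amine nitrogen does not bring back a readable value. The step between the two open-chain compounds cannot be read, as both stand at the limit: the limit of > 10000 nM in this assay, at which 2 of the 3 values shown sit.

Any effect of ethyl at this position remains hidden. As far as these compounds go, whether a longer chain or dimethylamino in place of propylamino would give a readable value remains open.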